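Adding a propylamino group to a weak pyridine amide

The source may report more compounds than this note shows. Statements on the series, on what has been measured and on what is new or still open speak of the compounds shown alone.

Among the compounds with values here, compound 1, `C=CCOc1ccc(C(=O)Nc2ccccn2)cc1`, is the only compound in this set with a numeric result: in an in vitro assay on HEK-tsA201 cells for antagonist activity at Neuronal acetylcholine receptor; alpha4/beta2 (Homo sapiens), read by fluorescence and calcium flux (on this read-out higher numbers stand for weaker inhibition and lower numbers for stronger inhibition), compound 1 gives 19300 nM. Compound 2, `CCCOc1ccc(C(=O)Nc2cccc(Nc3ccccc3F)n2)cc1`, reaches only a limit of the assay, giving > 100000 nM in this assay. Compound 3, `CCCOc1ccc(C(=O)Nc2cccc(Nc3ccc(F)cc3)n2)cc1`, likewise stops at a limit, giving > 100000 nM in this assay. Compounds 2 and 3 differ from one another only in the fluorine position, and the step that the two limits leave unreadable from compound 2 to compound 3 cannot be sized, since both values sit at the limit of > 100000 nM in this assay, at which 2 of the 3 values shown sit. Compound 4, `C=CCOc1ccc(C(=O)Nc2cccc(NCCC)n2)cc1`, is not yet measured; it differs from compound 1 by propylamino in place of hydrogen on an aromatic carbon, the same ring position that carries an arylamino group in compounds 2 and 3. Within the data shown here, no measured step isolates this change, yet the only two compounds bearing an amino substituent at that position both sit at the limit. The expected step of a 3.1-fold higher number from compound 1 to compound 4 (0.49 log units; beyond the scatter) from compound 1 to compound 4 is therefore toward weaker inhibition. Compound 4 is estimated at 60000 nM, within 15000 nM to 150000 nM.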

Compound 4, half-maximal inhibitory concentration: 14800 nM
Estimate against measurement, compound 4: 4.1-fold (0.61 log units) above; measured number below the stated range.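

In this assay, placing propylamino in place of hydrogen on the aromatic carbon next to the ring nitrogen gives a 1.3-fold lower number from compound 1 to compound 4 (0.12 log units; within the scatter), so compound 1 and compound 4 cannot be told apart. Within the data shown here, this position can therefore carry an amino substituent with no measurable loss of inhibition, which the earlier compounds could not show. Compound 2 and compound 3 differ from compound 4 in more than one place, so their results are limits that cannot be set against it: the limit of > 100000 nM in this assay, at which 2 of the 4 values shown sit.

On these data alone, it remains open whether the fluorophenylamino group, the propoxy group in place of the allyloxy group, or the two together separate those compounds from compound 4. As far as these compounds go, it is also open whether a plain amino group or a longer chain such as butylamino on this carbon would change the result beyond the scatter.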